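The compounds below may be only part of what the source reports. "The series", "measured", "known", "first", "only" and "open" are said of these compounds alone.

Measured so far:

Compound 1, `CCCCc1oc2ccccc2c1C(=O)c1ccc(OCC(=O)N2CCCC2)cc1`: 42400 nM
Compound 2, `CCCCc1oc2ccccc2c1C(=O)c1ccc(OCC(=O)N2CCCCC2)cc1`: > 50000 nM
Compound 3, `CCCCc1oc2ccccc2c1C(=O)c1ccc(OCCCC(=O)N2CCCC2)cc1`: 23500 nM

All three were tested in a functional assay on MCF7 cells (Homo sapiens) for antiproliferative activity, read by MTT assay, with a stated time of 24 h; a higher number here means a weaker inhibitor, a lower number a stronger inhibitor. Compound 1 gives 42400 nM in this assay. Compound 2 reaches only the limit of the assay, > 50000 nM, and no number is reported for it. Compound 3 gives 23500 nM. The step from compound 1 to compound 2 is an at least 1.1-fold higher number from compound 1 to compound 2 (0.07 log units; that floor lies within the scatter), and the structural change behind it is piperidin-1-yl in place of pyrrolidin-1-yl on a carbonyl carbon. Between compound 1 and compound 3 the core differs as 2-((pyrrolidin-1-yl)carbonyl)ethyl in place of (pyrrolidin-1-yl)carbonyl on a saturated chain carbon bound to an oxygen on an aromatic ring, and the step is a 1.8-fold lower number from compound 1 to compound 3 (0.26 log units; within the scatter). From compound 2 to compound 3 the step is an at least 2.1-fold lower number from compound 2 to compound 3 (0.32 log units; beyond the scatter).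

Compound 4, `CCCCc1oc2ccccc2c1C(=O)c1ccc(OCCCC(=O)N2CCCCC2)cc1`, has not yet been measured in this assay. It differs from compound 3 by piperidin-1-yl in place of pyrrolidin-1-yl on a carbonyl carbon, which is the same change as that from compound 1 to compound 2, made on the same kind of carbonyl carbon. Because the earlier step was an at least 1.1-fold higher number from compound 1 to compound 2 (0.07 log units; that floor lies within the scatter), and because the limit of > 50000 nM in this assay, at which 1 of the 3 values shown sits, shows that the value of compound 2 is a limit, only the lower bound of that step is known. The estimate for compound 4 therefore rests on a step of about the same size or somewhat larger, with wide uncertainty: compound 4 is expected to show a 1.4-fold higher number from compound 3 to compound 4 (0.13 log units; within the scatter) relative to compound 3. Compound 4 is expected to give about 32000 nM in this assay, within a range estimated from 15000 nM to 65000 nM.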

Compound 4, half-maximal inhibitory concentration: 33000 nM
For compound 4 the middle estimate is 1.0-fold (0.01 log units) below the measured one; low and high end bracket the measured number.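

In this assay, piperidin-1-yl in place of pyrrolidin-1-yl on the carbonyl carbon gives a 1.4-fold higher number from compound 3 to compound 4 (0.15 log units; within the scatter); the 2-((piperidin-1-yl)carbonyl)ethyl group gives an at least 1.5-fold lower number from compound 2 to compound 4 (0.18 log units; that floor lies within the scatter) when it replaces (piperidin-1-yl)carbonyl, and a 1.3-fold lower number from compound 1 to compound 4 (0.11 log units; within the scatter) when it replaces (pyrrolidin-1-yl)carbonyl. Set beside the earlier step, the ring change on the two cores compares as follows: the same change on two cores in this assay, an at least 1.1-fold higher number (0.07 log units; that floor lies within the scatter) from compound 1 to compound 2 and a 1.4-fold higher number (0.15 log units; within the scatter) from compound 3 to compound 4; the limit leaves it open whether they differ. Compound 2 sits at a limit of the assay, > 50000 nM, so the data show no disagreement between the two cores but do not show that the change carries over at the same size: the limit of > 50000 nM in this assay, at which 1 of the 4 values shown sits.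

The compounds shown leave open how a morpholine ring or an open-chain diethylamine amide would compare with pyrrolidin-1-yl and piperidin-1-yl on the same carbonyl carbon. They also leave open whether the ring change would read the same on a longer chain than 2-((pyrrolidin-1-yl)carbonyl)ethyl, or with a carboxylic acid in place of the amide.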